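Bromophenyl in place of methoxyphenyl on a shared core

The source may report more compounds than this note shows. Statements on the series, on what has been measured and on what is new or still open speak of the compounds shown alone.

In a functional assay on MCF7 cells (Homo sapiens) for cytotoxicity, read by CCK-8 assay, with a stated time of 72 h (a lower number here means a stronger inhibitor, a higher number a weaker inhibitor), compound 3 `C=CCn1c(=O)/c(=C\c2ccccc2OC)[nH]c(=O)/c1=C\c1ccccc1OC` gives 41100 nM, the higher of the two numbers recorded here. Compound 1 `C=CCn1c(=O)/c(=C\c2cccc(F)c2)[nH]c(=O)/c1=C\c1ccccc1OC` gives 13700 nM, and compound 2 `C=CCn1c(=O)/c(=C\c2ccc(Cl)c(Cl)c2)[nH]c(=O)/c1=C\c1ccccc1OC` is reported as "not active" (no number reported) with no number given. Compound 4 `C=CCn1c(=O)/c(=C\c2cccc(Br)c2)[nH]c(=O)/c1=C\c1ccccc1OC` differs from compound 3 in one place: 3-bromophenyl in place of 2-methoxyphenyl on a double-bonded chain carbon bound to an aromatic carbon. Within the data shown here, the only measured step that bears on this is a 3.0-fold higher number from compound 1 to compound 3 (0.48 log units; beyond the scatter), which ran the opposite way with a fluorine in the same ring type. Because compound 1 gave 13700 nM with 3-fluorophenyl in that place, the bromine analogue is expected to move back toward it, by about a 2.7-fold lower number from compound 3 to compound 4 (0.44 log units; beyond the scatter), though compound 2 warns that halogenated rings do not always keep activity. Compound 4 is therefore estimated at 15000 nM in this assay, between 5000 nM and 50000 nM.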

Compound 4, half-maximal inhibitory concentration: 5400 nM
Beside the measured number, compound 4's estimate is 2.8-fold (0.44 log units) above it, within the range that was stated.
By their numbers in this assay, from the lowest: compound 4; then compound 1; then compound 3.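

In this assay the halogen itself matters at this place, not only the loss of the methoxy group: the 3-bromophenyl group gives a 7.6-fold lower number from compound 3 to compound 4 (0.88 log units; beyond the scatter) and, against the fluorine analogue, a 2.5-fold lower number from compound 1 to compound 4 (0.40 log units; beyond the scatter) on the same ring type. Among these compounds, compound 4 thus has the lowest number so far, although the chlorinated ring of compound 2, reported as not active, goes against any general gain from halogens. No measurement on hand explains this difference.

From the compounds shown here alone, it remains open whether an amine or a carboxylic acid on this ring would keep the activity.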